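Phenyl Added Two Bonds Out Along the Chain

The source may report more compounds than this note shows. Statements on the series, on what has been measured and on what is new or still open speak of the compounds shown alone.

Measured so far:
compound 1 `CN(c1ccncc1)n1cccc1`, > 20 mg/kg
compound 2 `c1ccc(CN(c2ccncc2)n2cccc2)cc1`, > 20 mg/kg
compound 3 `CCc1cccn1N(C)c1ccncc1`, > 20 mg/kg

In a functional assay on the whole organism with Mus musculus as the target (a lower number here means that less compound is needed, a higher number that more compound is needed for the effect), compound 1 reaches only a limit, not a number. Compound 2 likewise stops at a limit in this assay. Compound 3 too is reported only as a limit. The change from compound 1 to compound 2 is phenyl in place of hydrogen on a saturated chain carbon bound to a nitrogen on an aromatic ring, and the step it made is a step that the two limits leave unreadable from compound 1 to compound 2. The cores of compound 1 and compound 3 differ by ethyl in place of hydrogen on an aromatic carbon, with the step that the two limits leave unreadable from compound 1 to compound 3. Compound 4 `CN(c1ccncc1)n1cccc1CCc1ccccc1` is not yet measured; it differs from compound 3 by phenyl in place of hydrogen on a saturated chain carbon, two bonds along the chain from an aromatic carbon. This is the same kind of change as that from compound 1 to compound 2, but not the same: there the phenyl enters on a saturated chain carbon bound to a nitrogen on an aromatic ring, here on a saturated chain carbon two bonds along the chain from an aromatic carbon. Because (the limit of > 20 mg/kg in this assay, at which 3 of the 3 values shown sit), no readable step is available in this assay. The expectation for compound 4 rests on compound 3 and on (the limit of > 20 mg/kg in this assay, at which 3 of the 3 values shown sit), and the expected step is a step that the limit leaves unreadable from compound 3 to compound 4. Compound 4 is expected near 30 mg/kg, between 10 mg/kg and 100 mg/kg, most likely again only as a limit.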

Compound 4, dose for half-maximal effect: > 20 mg/kg
Compound 4: a limit, no number; the forecaster's own chance of this, stated with the estimate: 75%; the middle value is on the limit's open side.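

No new step can be read from compound 3 to compound 4, because the result for compound 4 is again only a limit: the limit of > 20 mg/kg in this assay, at which 4 of the 4 values shown sit.

The compounds shown leave open what half-maximal dose any of the four would have in this assay, and so whether phenyl in place of hydrogen changes that dose at all.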